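Working notes on cytotoxicity in the compound 2 series

The source may hold more compounds than are shown below. What is called first, only, known or untested is meant among the compounds shown, and "the series" means these compounds.

Measured so far in a toxicity assay on MDCK cells (Canis lupus familiaris) for cytotoxicity, read by crystal violet staining, with a stated time of 48 h; on this read-out lower numbers stand for higher toxicity in this test and higher numbers for lower toxicity in this test:
compound 1 `CCc1ccc2[nH]c(=O)c(CN(Cc3ccc(F)cc3)Cc3ccc(-c4ccccc4)cc3)cc2c1` gives > 5000 nM.
compound 2 `Cc1ccc2[nH]c(=O)c(CN(CCCO)Cc3ccc(C(C)(C)C)cc3)cc2c1` gives > 10000 nM.
compound 3 `CCc1ccc2[nH]c(=O)c(CN(CCCO)Cc3ccc(C(C)(C)C)cc3)cc2c1` gives > 10000 nM.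

Each of these values is a limit of the assay, not a number. Compound 2 therefore stands at a limit in this assay, and nothing places it above or below its neighbours. The set as a whole shows only limits: the limit of > 10000 nM in this assay, at which 2 of the 3 values shown sit, and (the limit of > 5000 nM in this assay, at which 1 of the 3 values shown sits).

Compound 4 `COc1ccc(CN(Cc2ccc(C(C)(C)C)cc2)Cc2cc3cc(C)ccc3[nH]c2=O)cc1` differs from compound 2 by 4-methoxyphenyl in place of 2-hydroxyethyl on a saturated chain carbon bound to an amine nitrogen. For the measured compounds named here, the only measured step, a step that the two limits leave unreadable from compound 2 to compound 3, touches a different position and cannot be sized, so no measured step bears on this change. With no readable step anywhere, no step beyond the scatter is expected in this assay. Compound 4 is expected at 15000 nM, within 5000 nM to 50000 nM. The expected step is a step that the limit leaves unreadable from compound 2 to compound 4.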

Compound 4, half-maximal cytotoxic concentration: > 10000 nM
Compound 4 ended at the assay's limit (the forecaster's own chance of this, stated with the estimate: 70%); the middle value does not contradict the limit.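

For the compounds shown here, compound 2 and compound 4 both stand at a limit in this assay; no step between them can be read. The compounds shown leave open whether 4-methoxyphenyl in place of 2-hydroxyethyl changes cytotoxicity at all.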